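Returning to a Small Secondary Amide

The compounds below may be only part of what the source reports. "The series", "measured", "known", "first", "only" and "open" are said of these compounds alone.

Measured so far:
compound 1 `CCn1c(C(=O)NCC#N)ccc1C(CC)(CC)c1ccc(OCCC(O)(CC)CC)c(C)c1`: 17800 nM
compound 2 `CCn1c(C(=O)N(CCC#N)CCC#N)ccc1C(CC)(CC)c1ccc(OCCC(O)(CC)CC)c(C)c1`: > 50000 nM

In a functional assay on PC-3 cells (Homo sapiens) for antiproliferative activity, read by MTT assay, with a stated time of 48 h (a higher number here means a weaker inhibitor, a lower number a stronger inhibitor), compound 1 gives 17800 nM. Compound 2 gives only > 50000 nM, which is a limit of the assay and not a number. For the measured compounds named here, compound 2 therefore stands at the weaker end of the two results, because it sits at the limit of > 50000 nM in this assay, at which 1 of the 2 values shown sits, while the only measured step, an at least 2.8-fold higher number from compound 1 to compound 2 (0.44 log units; beyond the scatter), came from putting the larger group on the carbonyl carbon.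

Compound 3 `CCn1c(C(=O)NC(C)CO)ccc1C(CC)(CC)c1ccc(OCCC(O)(CC)CC)c(C)c1` differs from compound 2 by a group of 5 heavy atoms (3 carbon, 1 nitrogen, 1 oxygen; no ring) in place of a group of 9 heavy atoms (6 carbon, 3 nitrogen; no ring), on a carbonyl carbon. This change runs in the opposite sense to the measured step: a small group with two hydrogen-bond donors replaces the large group that went with the loss of activity. Going by the values given here, the measured step is the only guide, and it suggests that shrinking the group on the carbonyl carbon should bring the number back toward that of compound 1, so the expected step is an at least 2.5-fold lower number from compound 2 to compound 3 (0.39 log units; beyond the scatter). Compound 3 is thus estimated at 20000 nM, with a range from 8000 nM to 50000 nM.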

Compound 3, half-maximal inhibitory concentration: 7870 nM
Beside the measured number, compound 3's estimate is 2.5-fold (0.41 log units) above it; measured number outside the range, below it.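

For the compounds shown here, until now the only step at this carbonyl carbon was a loss, but in this assay the (1-(hydroxymethyl)ethyl)amino group moves the number the other way, with an at least 6.3-fold lower number from compound 2 to compound 3 (0.80 log units; beyond the scatter). That size is only a minimum, as compound 2 gives a limit of the assay and not a number: the limit of > 50000 nM in this assay, at which 1 of the 3 values shown sits. The more informative comparison is with the other secondary amide, since 1-(hydroxymethyl)ethyl in place of cyanomethyl on the amide-type nitrogen gives a 2.3-fold lower number from compound 1 to compound 3 (0.35 log units; beyond the scatter), which shows that the outcome depends on which small group is present and leaves compound 3 with the lowest number of the three.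

The compounds shown cannot separate the hydroxyl of the new group from its methyl branch, since both arrive in the same change, and a 2-hydroxyethyl or a plain propyl group on that nitrogen would pull the two apart. As far as these compounds go, it also remains open whether a chain ending in an amine or a carboxylic acid would lower the number further, or whether a longer hydroxyalkyl chain would keep the gain seen with compound 3.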